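The source may hold more compounds than are shown below. What is called first, only, known or untested is meant among the compounds shown, and "the series" means these compounds.

For the measured compounds named here, in an ADME assay on Vero cells (Chlorocebus sabaeus) for cytotoxicity, read by CellTiter-Glo, with a stated time of 72 h (a lower number here means that less compound is tolerated, a higher number that more compound is tolerated), compound 1 `CCNc1n[n+]([O-])c2ccccc2[n+]1[O-]` gives 17 ug/mL and compound 2 `CCNc1n[n+]([O-])c2cc(F)ccc2[n+]1[O-]` gives 4.6 ug/mL, the lower of the two numbers so far. Going by the values given here, the only measured step, a 3.7-fold lower number from compound 1 to compound 2 (0.57 log units; beyond the scatter), is modest and comes from fluoro in place of hydrogen on an aromatic carbon. Compound 3 `CCNc1n[n+]([O-])c2cc(Cl)ccc2[n+]1[O-]` keeps the core of compound 2 and has chloro in place of fluoro on an aromatic carbon. Among the compounds with values here, no measured step exchanges one of these groups for the other, so the step to compound 2 bears on this change only indirectly. With hydrogen already replaced in compound 2, no step beyond the scatter is expected in this assay. The estimated change is small and slightly downward, a 1.2-fold lower number from compound 2 to compound 3 (0.06 log units; within the scatter). For compound 3 the expected value is 4 ug/mL, with an estimated range of 1.5 ug/mL to 11 ug/mL.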

Compound 3, half-maximal cytotoxic concentration: 2.6 ug/mL
For compound 3 the middle estimate is 1.5-fold (0.19 log units) above the measured one; the measured number falls inside the stated range.
By their numbers in this assay, from the lowest: compounds 3 and 2 (each within the scatter of the next); then compound 1.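

In this assay, a second group on this aromatic carbon now gives a step from hydrogen that lies beyond the scatter: chloro in place of hydrogen gives a 6.5-fold lower number from compound 1 to compound 3 (0.82 log units; beyond the scatter). Exchanging the two groups directly gives a 1.8-fold lower number from compound 2 to compound 3 (0.25 log units; within the scatter), so this assay does not tell fluoro and chloro apart at this position, and the lower number seen with fluoro is no longer confined to that one group. Nothing in the information available accounts for either step.

What remains open is whether the lower number follows from any group placed on this carbon or only from these two, since a methoxy group or an amine is not among the compounds shown. Also open, on these data alone, is whether a longer chain in place of the ethylamino group would alter how far these steps carry.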